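Halogen swap at the aryl position in the shared core

The source may hold more compounds than are shown below. What is called first, only, known or untested is meant among the compounds shown, and "the series" means these compounds.

Three compounds of this series have numbers. Compound 1 `CC(C)Cc1ccc(C(C)c2nnc3n2N=C(c2ccc(OC(F)(F)F)cc2)CS3)cc1` gives 1100 nM in a functional assay on MCF7 cells (Homo sapiens) for inhibition, read by sulforhodamine B assay, with a stated time of 72 h; a lower number here means a stronger inhibitor, a higher number a weaker inhibitor. Compound 2 `COc1ccc2cc(C(C)c3nnc4n3N=C(c3ccc([N+](=O)[O-])cc3)CS4)ccc2c1`, on a different core, gives 18800 nM. Compound 3 `CC(C)Cc1ccc(C(C)c2nnc3n2N=C(c2ccc(Br)cc2)CS3)cc1` gives 9400 nM, the second highest of the three numbers; its gap to compound 2 is within the scatter, while the step of an 8.5-fold higher number from compound 1 to compound 3 (0.93 log units; beyond the scatter) is beyond it.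

Compound 4 `CC(C)Cc1ccc(C(C)c2nnc3n2N=C(c2ccc(F)cc2)CS3)cc1` has not been measured. It differs from compound 3 in one place: fluoro in place of bromo on an aromatic carbon.

Among the measured compounds shown here, no measured step exchanges one small substituent of this kind for another at that position. For the measured compounds named here, the only step that touches it, an 8.5-fold higher number from compound 1 to compound 3 (0.93 log units; beyond the scatter), shows that what sits on that aromatic carbon can move the number by a modest amount, but it says nothing about the direction for fluoro. The expectation is therefore a step of a 1.2-fold lower number from compound 3 to compound 4 (0.07 log units; within the scatter) that stays near the scatter, with a wide range either way. Compound 4 is estimated at 8000 nM, between 2500 nM and 25000 nM.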

Compound 4, half-maximal inhibitory concentration: 8900 nM
For compound 4 the middle estimate is 1.1-fold (0.05 log units) below the measured one, within the range that was stated.
By their numbers in this assay, from the lowest: compound 1; then compounds 4, 3 and 2 (each within the scatter of the next, the first and the last beyond it).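

In this assay, the change from 4-bromophenyl to 4-fluorophenyl gives a 1.1-fold lower number from compound 3 to compound 4 (0.02 log units; within the scatter), so these two halogens cannot be told apart on this aromatic carbon of the shared core. The separation from the trifluoromethoxy compound holds for fluoro as well as for bromo, with an 8.1-fold higher number from compound 1 to compound 4 (0.91 log units; beyond the scatter) beside the earlier 8.5-fold higher number from compound 1 to compound 3 (0.93 log units; beyond the scatter), and in this set of three compounds on the shared core only trifluoromethoxy stands apart from the others. No measurement at hand explains why trifluoromethoxy differs from the two halogens.

The compounds shown leave open whether the lower number of compound 1 goes with the oxygen link or with the fluorines it carries, which a methoxy or a trifluoromethyl group at this position could help to separate. They also leave open how an amine or a carboxylic acid on this carbon would read in this assay.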